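This account rests on a few compounds, and the source may have more. Where it says the series, first, only, none or still open, it means among the compounds named here.

Compound 2 `O=C(Nc1cccc(C(F)(F)F)c1)C(Cl)Cl` gives 143000 nM in a functional assay on BGC-823 cells (Homo sapiens) for antiproliferative activity, read by MTT assay, with a stated time of 72 h (a higher number here means a weaker inhibitor, a lower number a stronger inhibitor), and compound 1 `O=C(Nc1cccc(Br)c1)C(Cl)Cl` gives 95300 nM in this assay. Among the two numbers compound 2 has the higher one, but the step of a 1.5-fold higher number from compound 1 to compound 2 (0.18 log units; within the scatter) lies within the scatter, so the two compounds cannot be ordered on this evidence.

Compound 3 `O=C(Nc1cccc(SC(F)(F)F)c1)C(Cl)Cl` differs from compound 2 by (trifluoromethyl)sulfanyl in place of trifluoromethyl on an aromatic carbon. Within the data shown here, the only measured step that touches this position, a 1.5-fold higher number from compound 1 to compound 2 (0.18 log units; within the scatter), exchanged one substituent for another at the same aromatic carbon without moving the number beyond the scatter. Among the measured compounds shown here, no measured step speaks directly to a (trifluoromethyl)sulfanyl group, and the one comparison available argues for no change beyond the scatter.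

For the measured compounds named here, compound 3 is therefore expected to show a 1.2-fold lower number from compound 2 to compound 3 (0.08 log units; within the scatter), which is no real step in this assay. The estimate for compound 3 is 120000 nM, with a range from 40000 nM to 360000 nM.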

Compound 3, half-maximal inhibitory concentration: 123000 nM
Compound 3: middle estimate off by 1.0-fold (0.01 log units), on the low side; the measured number falls inside the stated range.
By their numbers in this assay, from the lowest: compounds 1, 3 and 2 (each within the scatter of the next).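

In this assay, putting (trifluoromethyl)sulfanyl in place of trifluoromethyl gives a 1.2-fold lower number from compound 2 to compound 3 (0.07 log units; within the scatter), and putting it in place of bromo gives a 1.3-fold higher number from compound 1 to compound 3 (0.11 log units; within the scatter). Among these compounds, the position has now carried three different groups, the newest with a sulfur atom and a hydrogen-bond acceptor that trifluoromethyl lacks, and all three numbers lie within the scatter of one another, which the single earlier step could not show. Nothing at hand explains this lack of a readable difference.

On these data alone, all three groups carry no net charge, so it remains open whether an amine or a carboxylic acid on this aromatic carbon would move the number beyond the scatter. As far as these compounds go, it also remains open whether a change elsewhere in the shared core would do so.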